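The source may hold more compounds than are shown below. What is called first, only, known or untested is meant among the compounds shown, and "the series" means these compounds.

Compound 1 `CCOC(=O)C1=C(C)NC(=S)NC1c1cn(C(=O)CNc2ccccc2)c2ccccc12` and compound 2 `CCOC(=O)C1=C(C)NC(=S)NC1c1cn(C(=O)CNc2ccc([N+](=O)[O-])cc2C)c2ccccc12` share one core and differ only in the group carried on an amine nitrogen. In a functional assay on HCT-116 cells (Homo sapiens) for cytotoxicity, read by MTT assay, with a stated time of 72 h (on this read-out higher numbers stand for weaker inhibition and lower numbers for stronger inhibition), compound 1 gives 450 ug/mL. For compound 2 this assay reports only a limit, > 1000 ug/mL. That places compound 2 at the limit of > 1000 ug/mL in this assay, at which 1 of the 2 values shown sits, so only a floor for its number is known. The step of an at least 2.2-fold higher number from compound 1 to compound 2 (0.34 log units; beyond the scatter) is therefore a weakening of at least modest size, with no ceiling to it. Compound 3 `CCOC(=O)C1=C(C)NC(=S)NC1c1cn(C(=O)CNc2ccccc2[N+](=O)[O-])c2ccccc12` has not yet been measured; it differs from compound 2 by 2-nitrophenyl in place of 2-methyl-4-nitrophenyl on an amine nitrogen. For the measured compounds named here, no measured step covers this exact change, so the only guide is that compound 1 sits well inside the measured range while compound 2 sits at the limit. The expected step of an at least 1.2-fold lower number from compound 2 to compound 3 (0.09 log units; that floor lies within the scatter) is uncertain in direction. Compound 3 is expected to give about 800 ug/mL, within 350 ug/mL to 1500 ug/mL.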

Compound 3, half-maximal inhibitory concentration: > 1000 ug/mL
Compound 3 gave a limit, no number (the forecaster's own chance of this, stated with the estimate: 45%); at least 1.2-fold (0.09 log units) between middle value and limit.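

Nitro in place of hydrogen on an aromatic carbon is by itself enough to weaken the compound in this assay, giving an at least 2.2-fold higher number from compound 1 to compound 3 (0.34 log units; beyond the scatter). The methyl group of compound 2 is therefore not needed for this loss: compound 3 lacks that methyl group, and its result is still only a limit, not a number. Both of the nitro-bearing compounds, 2-methyl-4-nitrophenyl in compound 2 and 2-nitrophenyl in compound 3, now stand at the same limit: the limit of > 1000 ug/mL in this assay, at which 2 of the 3 values shown sit.

As far as these compounds go, with two limits, the step between compound 2 and compound 3 cannot be read, so what the methyl group and the different nitro placement each contribute stays unknown. From the compounds shown here alone, it also remains open whether another group on that aromatic carbon, such as an amine or a carboxylic acid, would keep the number near that of compound 1.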